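The source may report more compounds than this note shows. Statements on the series, on what has been measured and on what is new or still open speak of the compounds shown alone.

Working notes on the series in a functional assay on SMMC-7721 cells (Homo sapiens) for cytotoxicity, read by MTT assay, with a stated time of 24 h; a lower number here means a stronger inhibitor, a higher number a weaker inhibitor.

For the measured compounds named here, compound 1 `COc1cc(/C=C2\CN(C)C/C(=C\c3cccnc3)C2=O)cc(OC)c1` gives 17900 nM in this assay, and compound 3 `COc1cc(/C=C2\CN(C)C/C(=C\c3ccncc3)C2=O)cc(OC)c1`, which carries pyridin-4-yl in place of pyridin-3-yl on a double-bonded chain carbon bound to a double-bonded ring carbon, gives 5810 nM; the step of a 3.1-fold lower number from compound 1 to compound 3 (0.49 log units; beyond the scatter) is the only measured instance of this change so far. Compound 2 `CN1C/C(=C\c2cccnc2)C(=O)/C(=C/c2ccccc2F)C1` gives 5420 nM; its value sits within the scatter of compound 3 and is beyond the scatter from compound 1. The difference between the core of compound 2 and the core of compound 1 is not broken down here.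

Compound 4 `CN1C/C(=C\c2ccncc2)C(=O)/C(=C/c2ccccc2F)C1` has not been measured. It carries pyridin-4-yl in place of pyridin-3-yl on a double-bonded chain carbon bound to a double-bonded ring carbon, the same change as between compound 1 and compound 3, at the same place. A step of a 2.2-fold lower number from compound 2 to compound 4 (0.34 log units; beyond the scatter) is expected from compound 2 to compound 4, resting on a 3.1-fold lower number from compound 1 to compound 3 (0.49 log units; beyond the scatter); the change has one measured instance only, so the range is kept wide. Compound 4 is estimated at 2500 nM, likely between 900 nM and 7000 nM.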

Compound 4, half-maximal inhibitory concentration: 7000 nM
Compound 4: middle estimate off by 2.8-fold (0.45 log units), on the low side; low and high end bracket the measured number.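

In this assay the step reads a 1.3-fold higher number from compound 2 to compound 4 (0.11 log units; within the scatter) for pyridin-4-yl in place of pyridin-3-yl, so the lower number seen on the core of compound 1 does not carry over to the core of compound 2. For the compounds shown here, with only one pair on each core, this does not show which part of the cores matters, and it gives no rule for a further core. What it does show is that, in these four compounds, the same change does not give the same step on the two cores: the same change on two cores in this assay, a 3.1-fold lower number (0.49 log units; beyond the scatter) from compound 1 to compound 3 and a 1.3-fold higher number (0.11 log units; within the scatter) from compound 2 to compound 4, 4.0-fold (0.60 log units) apart, beyond the scatter of two such steps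

Still open, on these data alone, is how pyridin-2-yl would behave at the same place on either core. Also open, as far as these compounds go, is whether an amine or a carboxylic acid on the other arylidene group would alter the step.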